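Swapping a benzimidazole arm for a short propyl chain

This account rests on a few compounds, and the source may have more. Where it says the series, first, only, none or still open, it means among the compounds named here.

Compound 2 `Cc1cc(N2CC[C@@H](C)[C@@H](N(C)c3ncnc4[nH]ccc34)C2)n2nc(SCc3nc4ccccc4[nH]3)nc2n1` gives 40200 nM in a toxicity assay on GES1 cells (Homo sapiens) for inhibition, read by MTT assay, with a stated time of 72 h (on this read-out lower numbers stand for stronger inhibition and higher numbers for weaker inhibition), the lowest of the two numbers shown. Compound 1 `Cc1cc(N2CC[C@@H](C)[C@@H](N(C)c3ncnc4[nH]ccc34)C2)n2nc(SCc3ccccc3)nc2n1` gives 67200 nM, with a 1.7-fold lower number from compound 1 to compound 2 (0.22 log units; within the scatter). Compound 3 `Cc1cc(N2CC[C@@H](C)[C@@H](N(C)c3ncnc4[nH]ccc34)C2)n2nc(SCc3ccccc3Br)nc2n1` reaches only the assay limit of > 100000 nM (the limit of > 100000 nM in this assay, at which 1 of the 3 values shown sits). Compound 4 `CCCSc1nc2nc(C)cc(N3CC[C@@H](C)[C@@H](N(C)c4ncnc5[nH]ccc45)C3)n2n1` differs from compound 2 by ethyl in place of 1H-benzimidazol-2-yl on a saturated chain carbon bound to a sulfur. Of the measured steps, the one from phenyl to benzimidazolyl stayed within the scatter, whereas an at least 2.4-fold higher number from compound 2 to compound 3 (0.39 log units; beyond the scatter); none removes the ring entirely, so a loss of the benzimidazole is expected to move the number upward, but only modestly. The step is expected to be a 1.6-fold higher number from compound 2 to compound 4 (0.21 log units; within the scatter). Compound 4 is therefore estimated at 65000 nM, with a range from 25000 nM to 150000 nM.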

Compound 4, half-maximal inhibitory concentration: 67100 nM
Compound 4: the middle estimate sits 1.0-fold (0.01 log units) below what was measured; low and high end bracket the measured number.
By their numbers in this assay, from the lowest: compounds 2, 4 and 1 (each within the scatter of the next). At a limit, above all of these: compound 3.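

In this assay, a ring on the saturated chain carbon bound to a sulfur proves unnecessary for a number in this range: the plain propyl arm matches both the benzimidazole arm (a 1.7-fold higher number from compound 2 to compound 4 (0.22 log units; within the scatter)) and the benzyl arm (a 1.0-fold lower number from compound 1 to compound 4 (0.00 log units; within the scatter)). Against the 2-bromophenyl arm only a floor can be read, as that value is a limit (an at least 1.4-fold lower number from compound 3 to compound 4 (0.17 log units; that floor lies within the scatter)): the limit of > 100000 nM in this assay, at which 1 of the 4 values shown sits. On these data alone, whether a longer chain, an amine or a carboxylic acid at this place would leave the number unchanged stays open.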